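The compounds below may be only part of what the source reports. "The series", "measured", "known", "first", "only" and "open" are said of these compounds alone.

Measured so far:
- compound 1, `COc1cc(-c2cc(/C=C/C(=O)c3ccc(N)cc3)[nH]n2)cc(OC)c1OC`: -15%
- compound 2, `COc1ccc(C(=O)/C=C/c2cc(-c3cc(OC)c(OC)c(OC)c3)n[nH]2)cc1OC`: -81%
- compound 3, `COc1ccc(C(=O)/C=C/c2cc(-c3cc(OC)c(OC)c(OC)c3)n[nH]2)cc1`: 21%

All three were tested in a functional assay on SK-MEL-2 cells (Homo sapiens) for cytotoxicity, read by sulforhodamine B assay, with a stated time of 48 h, tested at 10 uM; on this read-out higher numbers stand for a weaker effect at the one concentration tested and lower numbers for a stronger effect. Compound 1 gives -15%, the second highest of the three numbers; its nearest neighbour is compound 3, and the furthest is compound 2. The two measured steps that start from compound 1 were both large: a number 66 percentage points lower from compound 1 to compound 2 (beyond the scatter) and a number 36 percentage points higher from compound 1 to compound 3 (beyond the scatter). The third step, a number 102 percentage points higher from compound 2 to compound 3 (beyond the scatter), is the one whose wording matches the change now in question, although it sits on the other aromatic ring of the shared core.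

Compound 4, `COc1ccc(-c2cc(/C=C/C(=O)c3ccc(N)cc3)[nH]n2)cc1OC`, differs from compound 1 in a single place: hydrogen in place of methoxy on an aromatic carbon. The spot affected lies ortho to a methoxy group and meta to a large group, on the six-membered ring of carbon only.

Within the data shown here, only the step from compound 2 to compound 3 speaks to a methoxy being removed, and there the number rose by a large amount, toward a weaker effect. On that basis a step upward, beyond the scatter, is expected in this assay for compound 4, though smaller because a number 102 percentage points higher from compound 2 to compound 3 (beyond the scatter) sits on a different ring. The estimate for compound 4 is 35%, with a range from -10% to 80%, meaning an expected step of a number 50 percentage points higher from compound 1 to compound 4 (beyond the scatter).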

Compound 4, a percentage reported as activity, at one concentration (the size of the read-out at that concentration, not a potency): 46%
Estimate against measurement, compound 4: 11 percentage points below; the range from low to high includes it.
By their numbers in this assay, from the lowest: compound 2; then compound 1; then compound 3; then compound 4.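

In this assay, hydrogen in place of methoxy at this spot, ortho to a methoxy group, gives a number 61 percentage points higher from compound 1 to compound 4 (beyond the scatter), a shift toward a weaker effect, so the methoxy here is not a spare group on this core. Among these compounds, until now, the only view of this change came from a different aromatic ring, and the new step shows the number moving in the same direction at this second place, but not by the same amount: the same change on two cores in this assay, a number 102 percentage points higher (beyond the scatter) from compound 2 to compound 3 and a number 61 percentage points higher (beyond the scatter) from compound 1 to compound 4, 41 percentage points apart, beyond the scatter of two such steps The worth of a methoxy therefore cannot simply be carried over from one of these cases to the other, even though the change has the same name in both.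

The two steps differ both in which ring loses its methoxy and in what the rest of the molecule carries, so the compounds shown cannot tell which of these sets the gap between them. They also leave open whether this spot needs a methoxy as such, or whether a hydroxyl, an ethoxy or a fluorine there would keep the number as low as in compound 1.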